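The source may report more compounds than this note shows. Statements on the series, on what has been measured and on what is new or still open speak of the compounds shown alone.

Working notes on the series, read in a functional assay on PC-3 cells (Homo sapiens) for cytotoxicity, read by MTT assay, with a stated time of 72 h; on this read-out higher numbers stand for weaker inhibition and lower numbers for stronger inhibition. Compound 1 `CNC(=O)c1cc(Oc2ccc(NC(=O)c3nccc(-c4ccc([N+](=O)[O-])cc4)n3)cc2)ccn1` gives only a limit, > 100000 nM, and no number. Compound 2 `CNC(=O)c1cc(Oc2ccc(NC(=O)c3cc(-c4ccc(Cl)cc4)ncn3)cc2)ccn1` likewise gives only a limit, > 100000 nM. Among the measured compounds shown here, compound 3 `CCc1ccc(-c2cc(C(=O)Nc3ccc(Oc4ccnc(C(=O)NC)c4)c(F)c3)ncn2)cc1` is the one member with a number so far, 15600 nM. Compound 1 thus stands at the limit of the assay, so any step starting from it can be stated only loosely.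

Next comes compound 4 `CNC(=O)c1cc(Oc2ccc(NC(=O)c3nccc(-c4ccc(OC)cc4)n3)cc2)ccn1`, which keeps the core of compound 1 and changes one substituent, 4-nitrophenyl to 4-methoxyphenyl: methoxy in place of nitro on an aromatic carbon, para to a large group (methoxy in place of nitro on an aromatic carbon). For the measured compounds named here, no step between measured compounds is available to size this change. Going by the values given here, the expectation in this assay is therefore a small gain in inhibition or none that can be seen, and with compound 3 at 15600 nM as the only number, a result much stronger than that is not expected. The expected change is an at least 1.4-fold lower number from compound 1 to compound 4 (0.15 log units; that floor lies within the scatter), in the direction of stronger inhibition if it appears at all. For compound 4 the estimated value is 70000 nM, with an expected range of 20000 nM to 200000 nM, and a report of a limit alone is quite likely.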

Compound 4, half-maximal inhibitory concentration: 14200 nM
Beside the measured number, compound 4's estimate is 4.9-fold (0.69 log units) above it; the whole stated range lies above it.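

In this assay, among the compounds shown here, the para position of this aryl ring proves able to move the read-out: methoxy in place of nitro on an aromatic carbon, para to a large group, gives an at least 7.0-fold lower number from compound 1 to compound 4 (0.84 log units; beyond the scatter) on the shared core, a change that no earlier pair of compounds could size. Compound 1 gives > 100000 nM, which is a limit of the assay and not a number. The step is therefore a floor, and the full size of the change stays unknown, because one end of it rests on such a limit: the limit of > 100000 nM in this assay, at which 2 of the 4 values shown sit.

From the compounds shown here alone, with only nitro and methoxy compared at this place, it remains open whether the gain belongs to the arrival of methoxy or to the departure of nitro, and an amine, a hydroxyl or a longer chain such as ethoxy at the same place on the core of compound 4 would help to separate the two. Also open is whether the same exchange carries over to a different core, since the compounds shown offer this change on one core only.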